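Cyanophenyl Replacing Isopropyl on the Amide Nitrogen

This account rests on a few compounds, and the source may have more. Where it says the series, first, only, none or still open, it means among the compounds named here.

Compound 1 `CC(C)NC(=O)c1ccc(NCc2cncn2Cc2ccc(C#N)cc2)cc1-c1ccccc1` gives > 10 uM in a functional assay on NIH3T3 cells (Mus musculus) (a lower number here means that less compound is needed, a higher number that more compound is needed for the effect), a limit of the assay rather than a number.
Compound 2 `CSCC[C@H](NC(=O)c1ccc(CNCc2c[nH]cn2)cc1-c1ccccc1C)C(=O)O` gives > 25 uM in this assay, also a limit.
Compound 3 `CSCC[C@H](NC(=O)c1ccc(NCc2cncn2Cc2cccc(Cl)c2)cc1-c1ccccc1)C(=O)O` gives > 10 uM in this assay, again a limit.

Compound 1 therefore stands at the limit of > 10 uM in this assay, at which 2 of the 3 values shown sit. Compound 2 sits at the limit of > 25 uM in this assay, at which 1 of the 3 values shown sits. Among the compounds with values here, none of the three measured compounds yields a number, and no step between two measured compounds is available.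

Compound 4 `N#Cc1ccc(Cn2cncc2CNc2ccc(C(=O)Nc3cccc(C#N)c3)c(-c3ccccc3)c2)cc1` differs from compound 1 by 3-cyanophenyl in place of isopropyl on an amide-type nitrogen. Within the data shown here, with no measured step to lean on, the step that the limit leaves unreadable from compound 1 to compound 4 is expected to be none beyond the scatter. Compound 4 is accordingly estimated at 15 uM, within 3 uM to 60 uM, and is expected most often to be reported as a limit once more.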

Compound 4, concentration for half-maximal effect: > 10 uM
Compound 4 gave a limit, no number; the forecaster's own chance of this, stated with the estimate: 70%; the middle value is on the limit's open side.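

Within the data shown here, compound 4 gives > 10 uM in this assay, again a limit, and since compound 1 also stands at a limit, no step between them can be read. As far as these compounds go, whether 3-cyanophenyl in place of isopropyl changes the concentration needed remains open.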